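The source may report more compounds than this note shows. Statements on the series, on what has been measured and on what is new or still open speak of the compounds shown alone.

Of the compounds shown here, three built on one shared core have been measured in a functional assay on MCF7 cells (Homo sapiens) for antiproliferative activity, read by MTT assay, with a stated time of 24 h, tested at 50 uM; on this read-out lower numbers stand for a stronger effect and higher numbers for a weaker effect at the one concentration tested. Compound 1 `OC(CCn1nc2c(Br)c(Br)c(Br)c(Br)c2n1)c1cccc(Br)c1` gives 14%. Compound 2 `COc1cccc(C(O)CCn2nc3c(Br)c(Br)c(Br)c(Br)c3n2)c1` gives 22%, and compound 3 `OC(CCn1nc2c(Br)c(Br)c(Br)c(Br)c2n1)c1ccc(Br)cc1` gives 10%. Compound 1 stands second highest of these three numbers; the step of a number 4 percentage points lower from compound 1 to compound 3 (within the scatter) lies within the scatter, as does a number 8 percentage points higher from compound 1 to compound 2 (within the scatter). Going by the values given here, only the step of a number 12 percentage points lower from compound 2 to compound 3 (beyond the scatter) reaches beyond the scatter, and that modestly.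

Compound 4 `CC(O)CCn1nc2c(Br)c(Br)c(Br)c(Br)c2n1` has not yet been measured. It differs from compound 1 in one place: methyl in place of 3-bromophenyl on a saturated chain carbon bound to an oxygen on a saturated carbon and a saturated chain carbon. Among the compounds with values here, no measured step bears directly on this change. Each of the three steps exchanges one substituted phenyl for another substituted phenyl at the same place, and the widest of them, a number 12 percentage points lower from compound 2 to compound 3 (beyond the scatter), is modest. The change to compound 4 removes the aromatic ring altogether and leaves only a methyl, so the measured steps give no firm guide to its size or direction. Given that all three measured compounds sit in a narrow band of low numbers, compound 4 is expected to move somewhat upward, a number 16 percentage points higher from compound 1 to compound 4 (beyond the scatter), with wide uncertainty. The estimate for compound 4 in this assay is 30%, with a range from 8% to 60%.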

Compound 4, a percentage reported as activity, at one concentration (the size of the read-out at that concentration, not a potency): 90%
Estimate against measurement, compound 4: 60 percentage points below, outside the stated range (above it).
By their numbers in this assay, from the lowest: compounds 3, 1 and 2 (each within the scatter of the next, the first and the last beyond it); then compound 4.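

In this assay, the place on a saturated chain carbon bound to an oxygen on a saturated carbon and a saturated chain carbon proves far more sensitive than the phenyl-for-phenyl exchanges had shown, since methyl moves the read-out towards a much weaker effect whichever ring leaves: a number 76 percentage points higher from compound 1 to compound 4 (beyond the scatter) and a number 80 percentage points higher from compound 3 to compound 4 (beyond the scatter) and also a number 68 percentage points higher from compound 2 to compound 4 (beyond the scatter) in the same direction. Within these four compounds, then, a substituted phenyl at this place goes with the stronger effect, and which substituted phenyl it is counts for much less, the widest step among the three being only modest at a number 12 percentage points lower from compound 2 to compound 3 (beyond the scatter). Nothing at hand explains why the loss on going to methyl is so large.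

The change removes the six-membered aromatic ring and the bromine together, so an unsubstituted phenyl, a cyclohexyl or a longer chain such as n-butyl at this place would be needed to tell whether the ring itself or merely a larger group carries the effect. As far as these compounds go, the role of the hydroxyl on that same carbon also stays open, and a ketone there would bear on it.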